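Phenyl in place of methyl on compound 1

A few compounds are considered here, and "the series" means these few. Any claim that something is new, unique, unknown or untested is made for them only; others in the source may bear on it.

compound 1 `Cc1csc2nc(Cn3cnc4ccccc43)cc(=O)n12`: 8 mL.min-1.g-1
compound 2 `CCc1nn2c(=O)cc(Cn3cnc4ccccc43)nc2s1`: 8 mL.min-1.g-1

In an ADME assay on microsomes from liver (Homo sapiens) for metabolic stability (a higher number here means faster removal of the compound, a lower number slower removal), compound 1 gives 8 mL.min-1.g-1, level with compound 2 within the scatter. Compound 3 `O=c1cc(Cn2cnc3ccccc32)nc2scc(-c3ccccc3)n12` has phenyl in place of methyl on an aromatic carbon. For the measured compounds named here, no measured step sizes this change, so the expectation rests on the structural change alone and stays loose. A modest rise in this assay is expected, only just beyond the scatter. The estimated step is a 2.3-fold higher number from compound 1 to compound 3 (0.35 log units; beyond the scatter). Compound 3 is estimated at 18 mL.min-1.g-1, with an expected range of 8 mL.min-1.g-1 to 40 mL.min-1.g-1.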

Compound 3, intrinsic clearance in microsomes: 8 mL.min-1.g-1
Compound 3: the middle estimate sits 2.3-fold (0.35 log units) above what was measured; the range from low to high includes it.
By their numbers in this assay, from the lowest: compounds 1, 2 and 3 (each within the scatter of the next).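

In this assay, phenyl in place of methyl on an aromatic carbon, next to the ring nitrogen, gives no change at the digits printed from compound 1 to compound 3 (within the scatter). For the compounds shown here, this position on the shared core therefore accepts a six-membered aromatic ring of carbon only, with no step beyond the scatter, which the earlier compounds could not show. Nothing measured here bears on the reason for this result. Still open, from the compounds shown here alone, is whether an amine or a carboxylic acid at this position would also stay level with methyl in this assay. The same question holds for a pyridine ring in place of phenyl.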